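The source may report more compounds than this note shows. Statements on the series, on what has been measured and on what is new or still open speak of the compounds shown alone.

Compound 1 `FC(F)(F)c1cccnc1N1CCC(NC(=S)Nc2cccnc2)CC1` was tested in an assay on membranes from brain for binding affinity to Lysophosphatidylserine lipase ABHD12 (Mus musculus), read by fluorescence, with a stated time of 20 min; on this read-out higher numbers stand for weaker inhibition and lower numbers for stronger inhibition. In this assay compound 1 gives only a limit, > 5000 nM, and not a number. Among the three measured compounds it therefore stands at the weak end, the point described by the limit of > 5000 nM in this assay, at which 1 of the 3 values shown sits. The two other measured compounds are larger molecules that share part of the same core. Compound 2 `FC(F)(F)Oc1ccc(Oc2ccnc(N3CCC(NC(=S)Nc4cccnc4)CC3)c2Cl)cc1` gives in this assay 25 nM. Compound 3 `FC(F)(F)Oc1ccc(Oc2ccnc(N3CCC[C@@H](NC(=S)Nc4cccnc4)C3)c2Cl)c(Cl)c1` gives in this assay 100000 nM. Compound 4 `S=C(Nc1cccnc1)NC1CCN(c2ncccc2Cl)CC1` has not yet been measured. It differs from compound 1 in a single place: chloro in place of trifluoromethyl on an aromatic carbon. Among the measured compounds shown here, no measured pair differs in just this way, so the size of this step is not known from the data. The change is small, and the step from compound 1 to compound 4 is expected to be a step that the limit leaves unreadable from compound 1 to compound 4, that is, nothing beyond the scatter, with a real chance that only a limit is reported again. Compound 4 is thus expected to give about 10000 nM, somewhere between 2000 nM and 50000 nM.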

Compound 4, half-maximal inhibitory concentration: > 5000 nM
Compound 4 gave a limit, no number; the forecaster's own chance of this, stated with the estimate: 70%; the middle value does not contradict the limit.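

Compound 1 and compound 4 both give only a limit in this assay, not a number, so no step between them can be read: the limit of > 5000 nM in this assay, at which 2 of the 4 values shown sit.

The compounds shown leave open whether chloro in place of trifluoromethyl on this aromatic carbon changes inhibition at all.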